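The source may report more compounds than this note shows. Statements on the series, on what has been measured and on what is new or still open speak of the compounds shown alone.

Notes on the series. For the measured compounds named here, compound 1 `Nc1ccccc1NC(=O)CCCNCC(=O)Nc1cc(Cl)ccc1Cl` and compound 2 `Cc1ccc(NC(=O)CNc2ccc(C(=O)Nc3ccccc3N)cc2)cc1` are the two members measured so far in a functional assay on U-251 cells (Homo sapiens) for inhibition, read by MTT assay, with a stated time of 2 days; a higher number here means a weaker inhibitor of growth, a lower number a stronger inhibitor of growth. In this assay compound 1 gives 44000 nM and compound 2 gives 84000 nM. Compound 1 holds the lower of the two numbers, but its gap to compound 2 lies within the usual scatter, so the two cannot be told apart on these data.

Compound 3 `Nc1ccccc1NC(=O)CCCNCC(=O)Nc1cccc([N+](=O)[O-])c1` is still to be measured in this assay. It differs from compound 1 in one place: 3-nitrophenyl in place of 2,5-dichlorophenyl on an amide-type nitrogen. Going by the values given here, no pair of measured compounds that differ in a single place exists, so the size of a step of this kind cannot be read from the data; the two measured values show only that both compounds land at comparable, high concentrations.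

Without a step to lean on, the estimated step from compound 1 to compound 3 is a 1.3-fold higher number from compound 1 to compound 3 (0.10 log units; within the scatter), which is expected to stay within the scatter. Compound 3 is therefore expected to give 55000 nM, with a range from 20000 nM to 150000 nM.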

Compound 3, concentration for 50% growth inhibition: 15000 nM
For compound 3 the middle estimate is 3.7-fold (0.56 log units) above the measured one, and the stated range ends above it.
By their numbers in this assay, from the lowest: compound 3; then compounds 1 and 2 (each within the scatter of the next).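

On the amide-type nitrogen, the series now has its first readable single change: in this assay, 3-nitrophenyl in place of 2,5-dichlorophenyl gives a 2.9-fold lower number from compound 1 to compound 3 (0.47 log units; beyond the scatter) with the rest of the structure held constant. This shows that the aryl group at this place can move the growth-inhibition number by more than the scatter, which the earlier pair of compounds, differing in more than one place, could not show. The step has a single direction and comes from one pair, and the change removes both chlorines while introducing the nitro group, so it cannot be assigned to either part of the swap; nothing measured here bears on the reason for the step.

From the compounds shown here alone, it remains open whether the lower number belongs to the nitro group itself or would also follow from removing the chlorines, which a plain phenyl at this nitrogen would help separate. Also open, going by these compounds, is whether other groups on the aromatic ring, such as a nitrile, a carboxylic acid or an amine, would move the number in the same direction, and whether the same swap carries over to the core of compound 2.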